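An aryl urea in place of the acetamide on the shared core

A few compounds are considered here, and "the series" means these few. Any claim that something is new, unique, unknown or untested is made for them only; others in the source may bear on it.

The compounds share one core carrying a chloro substituent and a dimethyl group, and they are compared in a functional assay on T98G cells (Homo sapiens) for inhibition, read by MTT assay, with a stated time of 72 h; a higher number here means a weaker inhibitor, a lower number a stronger inhibitor. Compound 1 `CC1(C)CC(NC(=O)NCc2ccccc2)c2cc(Cl)ccc2O1` carries a benzyl urea and gives 15000 nM. Compound 2 `CC1(C)CC(NC(=O)Nc2cccc(Cl)c2)c2cc(Cl)ccc2O1` carries a 3-chlorophenyl urea; in this assay compound 2 gives 25000 nM. Among the compounds with values here, the step of a 1.7-fold higher number from compound 1 to compound 2 (0.22 log units; within the scatter) is the only single-place comparison available. Compound 3 `CC(=O)NC1CC(C)(C)Oc2ccc(Cl)cc21` is the acetamide of the same core; in this assay compound 3 has "not determined" (no result reported), so it stands nowhere on the numbers shown and the step from it to compound 4 starts from an unknown point.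

Compound 4 `CC1(C)CC(NC(=O)Nc2ccc(Cl)cc2)c2cc(Cl)ccc2O1` differs from compound 3 in one place: (4-chlorophenyl)amino in place of methyl on a carbonyl carbon. The result is a urea, a close relative of compound 1 and compound 2. The measured step bears on it only indirectly: exchanging benzyl for 3-chlorophenyl on the amide-type nitrogen left the number within the scatter, so both ureas sit in the same region. Within the data shown here, no measured step relates an acetamide to a urea, so no direction can be given for this step itself. The number for compound 4 is expected to lie near those of the two ureas, estimated at 25000 nM with a range from 10000 nM to 60000 nM.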

Compound 4, half-maximal inhibitory concentration: 33000 nM
Beside the measured number, compound 4's estimate is 1.3-fold (0.12 log units) below it; the range from low to high includes it.
By their numbers in this assay, from the lowest: compounds 1, 2 and 4 (each within the scatter of the next, the first and the last beyond it).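

In this assay, exchanging 3-chlorophenyl for 4-chlorophenyl on the amide-type nitrogen gives a 1.3-fold higher number from compound 2 to compound 4 (0.12 log units; within the scatter) and so does not separate these two chlorophenyl ureas. Within the data shown here, the exchange of benzyl for 4-chlorophenyl gives a 2.2-fold higher number from compound 1 to compound 4 (0.34 log units; beyond the scatter) and is the first step here to pass the scatter, though only modestly, so this position shows a small measurable difference in the weaker direction for compound 4. That is no general rule for a chlorophenyl in place of benzyl, as compound 2 goes against it: a 1.7-fold higher number from compound 1 to compound 2 (0.22 log units; within the scatter) stays within the scatter. No measurement shown here accounts for these differences.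

Compound 3 has no number, so the step from the acetamide to a urea cannot be read, and the compounds shown do not tell what the urea itself contributes. They also leave open whether an unsubstituted phenyl, a 4-methoxyphenyl, a carboxylic acid or a longer chain between the nitrogen and the ring would move the number at this position.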